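Compound 4 Expected After a Sulfonyl Replaces a Sulfanyl

This account rests on a few compounds, and the source may have more. Where it says the series, first, only, none or still open, it means among the compounds named here.

Measured compounds in a functional assay on DU-145 cells (Homo sapiens) for inhibition, read by trypan blue exclusion, with a stated time of 96 h; a lower number here means a stronger inhibitor of growth, a higher number a weaker inhibitor of growth:
compound 1, `O=C(/C(=C\c1ccc([N+](=O)[O-])c(O)c1)SCc1ccc(Br)cc1)c1ccc(Br)cc1`, gives 10000 nM;
compound 2, `O=C(/C(=C\c1ccc(O)c([N+](=O)[O-])c1)Sc1ccccc1Br)c1ccc(Br)cc1`, gives 10000 nM;
compound 3, `Cc1cc(C)cc(/C=C(\C(=O)c2ccc(Cl)cc2)S(=O)(=O)Cc2ccc(Cl)cc2)c1`, gives 1000 nM.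

Compound 2 stands level with compound 1 at the digits shown, and the two of them share the highest number of the three. Among the measured compounds shown here, compound 3 is the furthest from compound 2, with a lower number that lies beyond the scatter; no single-change step joins compound 3 to compound 2, so their two values can only be set side by side.

Compound 4 is `O=C(/C(=C\c1ccc(O)c([N+](=O)[O-])c1)S(=O)(=O)c1ccc(I)cc1)c1ccc(Br)cc1`, not yet measured in this assay. It differs from compound 2 in one place: (4-iodophenyl)sulfonyl in place of (2-bromophenyl)sulfanyl on a double-bonded chain carbon bound to a carbonyl carbon and a double-bonded chain carbon. Compound 3 also carries a sulfonyl on the double-bonded chain carbon and gives 1000 nM, although it differs from compound 2 elsewhere as well. On that basis the account expects compound 4 to move toward a lower number than compound 2, by a moderate step of a 2.5-fold lower number from compound 2 to compound 4 (0.40 log units; beyond the scatter), a step that may reach beyond the scatter but is far from certain. Compound 4 is therefore estimated at 4000 nM in this assay, within a range from 1000 nM to 15000 nM.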

Compound 4, concentration for 50% growth inhibition: 25000 nM
Compound 4: the middle estimate sits 6.3-fold (0.80 log units) below what was measured; the whole stated range lies below it.
By their numbers in this assay, from the lowest: compound 3; then compounds 1 and 2 (each within the scatter of the next); then compound 4.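

The step at this place, on a double-bonded chain carbon bound to a carbonyl carbon and a double-bonded chain carbon, gives the series its first comparison of compounds that differ in one place: in this assay it is a 2.5-fold higher number from compound 2 to compound 4 (0.40 log units; beyond the scatter), so (4-iodophenyl)sulfonyl in place of (2-bromophenyl)sulfanyl weakens growth inhibition modestly. A sulfonyl on this carbon therefore does not bring a lower number on the core of compound 2 when it arrives with a 4-iodophenyl ring, although this one exchange alters the sulfur, the halogen and the halogen's ring position together and cannot divide the rise among them. Nothing available here explains the rise.

On these data alone, how much of it belongs to the sulfonyl and how much to the iodine remains open, and (2-bromophenyl)sulfonyl and (4-iodophenyl)sulfanyl at this place are the groups that would separate the two. Whether the direction would hold for a plain phenylsulfonyl, a benzylsulfonyl or a methylsulfonyl on the same carbon also remains unanswered.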